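A few compounds are considered here, and "the series" means these few. Any claim that something is new, unique, unknown or untested is made for them only; others in the source may bear on it.

Measured compounds in an assay on CHO cells for antagonist activity at transient receptor potential cation channel subfamily V member 1 (Homo sapiens), read by FLIPR; a lower number here means a stronger inhibitor, a higher number a weaker inhibitor: compound 1 `CC(C)CCOc1cc(C(F)(F)F)ccc1CNC(=O)C(C)c1ccc(NS(C)(=O)=O)c(F)c1` gives 0.5 nM; compound 2 `CC(C(=O)NCc1ccc(C(F)(F)F)cc1SCc1ccccc1)c1ccc(NS(C)(=O)=O)c(F)c1` gives 0.5 nM.

Compound 2 stands level with compound 1 on the numbers shown; the only step measured so far, no change at the digits printed from compound 1 to compound 2 (within the scatter), lies within the scatter, so the series has yet to show a change in this assay that can be read as real.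

The next compound, compound 3 `CC(C(=O)NCc1ccc(C(F)(F)F)cc1-c1ccc(C(C)(C)C)cc1)c1ccc(NS(C)(=O)=O)c(F)c1`, differs from compound 2 in one place: 4-(tert-butyl)phenyl in place of benzylsulfanyl on an aromatic carbon. The entering group sits on an aromatic carbon of a six-membered aromatic ring of carbon only, ortho to a large group and meta to a trifluoromethyl group.

Among the measured compounds shown here, only one measured step bears on this change, the exchange of groups at the same aromatic carbon from compound 1 to compound 2, and it was flat. The data therefore give no measured reason to expect a step beyond the scatter for compound 3, and the estimated step of a 2.0-fold higher number from compound 2 to compound 3 (0.30 log units; within the scatter) is set near zero with a range wide enough to allow some loss. In this assay compound 3 is expected to give 1 nM, between 0.3 nM and 5 nM.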

Compound 3, inhibition constant: 1.1 nM
The estimate for compound 3 lay 1.1-fold (0.04 log units) below the measured number, and the stated range covers the measured number.
By their numbers in this assay, from the lowest: compounds 1 and 2 (each within the scatter of the next); then compound 3.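

In this assay, this aromatic carbon, ortho to a large group and meta to a trifluoromethyl group, now shows its first change beyond the scatter: 4-(tert-butyl)phenyl in place of benzylsulfanyl gives a 2.2-fold higher number from compound 2 to compound 3 (0.34 log units; beyond the scatter), and 4-(tert-butyl)phenyl in place of isopentyloxy gives a 2.2-fold higher number from compound 1 to compound 3 (0.34 log units; beyond the scatter). The position is therefore not wholly indifferent to the group it carries, although the change is modest and compound 3 still reads 1.1 nM, so three differently built groups are all accepted here with only a small shift in the number. Nothing measured accounts for the higher number of compound 3, and the two steps share the same entering group, so they do not show which part of that group matters.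

As far as these compounds go, it remains open whether the shift belongs to the tert-butyl group or to the phenyl ring itself, a question that an unsubstituted phenyl at this carbon would address. It is also open how this position would respond to an amine such as piperidine or morpholine, or to a carboxylic acid on a longer chain, since all three groups shown carry only carbon beyond their linking atom.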